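Removing a methyl from the oxygen of compound 2

The source may hold more compounds than are shown below. What is called first, only, known or untested is meant among the compounds shown, and "the series" means these compounds.

Measured compounds:
compound 1 `O=C(Nc1cccc(-n2cc(-c3ccncc3)c(-c3ccc(Cl)c(O)c3)n2)c1)Nc1ccc(Cl)c(Cl)c1`: 1100 nM
compound 2 `COc1cc(-c2nn(-c3cccc(NC(=O)Nc4ccc(Cl)c(C(F)(F)F)c4)c3)cc2-c2ccncc2)ccc1Cl`: 683 nM

Of the compounds shown here, two have been tested in a functional assay on MDA-MB-435 cells (Homo sapiens) for inhibition, read by sulforhodamine B assay, with a stated time of 48 h; on this read-out higher numbers stand for weaker inhibition of growth and lower numbers for stronger inhibition of growth. Compound 1 gives 1100 nM and compound 2 gives 683 nM. Compound 2 has the lower of the two numbers, yet its gap to compound 1 lies within the usual scatter, so the two cannot be ranked on these data. For the measured compounds named here, the two also differ in two places at once, so no single step between them can be read off.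

Compound 3 `O=C(Nc1cccc(-n2cc(-c3ccncc3)c(-c3ccc(Cl)c(O)c3)n2)c1)Nc1ccc(Cl)c(C(F)(F)F)c1` is not yet measured. It differs from compound 2 by hydrogen in place of methyl on an oxygen on an aromatic ring. Going by the values given here, no measured pair shows this change on its own, so nothing here tells its size or direction. For compound 3 the expected step of a 1.3-fold higher number from compound 2 to compound 3 (0.12 log units; within the scatter) is none beyond the scatter, and the estimated value is 900 nM, within 400 nM to 2200 nM.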

Compound 3, concentration for 50% growth inhibition: 660 nM
Estimate against measurement, compound 3: 1.4-fold (0.13 log units) above; the range from low to high includes it.
By their numbers in this assay, from the lowest: compounds 3, 2 and 1 (each within the scatter of the next).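

In this assay, exchanging methoxy for hydroxy on the aromatic ring gives a 1.0-fold lower number from compound 2 to compound 3 (0.01 log units; within the scatter), so on this pair the methyl on that oxygen makes no readable difference to the number. Trifluoromethyl in place of chloro on an aromatic carbon, the other difference between the first two compounds, now stands alone and gives a 1.7-fold lower number from compound 1 to compound 3 (0.22 log units; within the scatter), so this exchange cannot be told apart from the scatter either, and each of the two differences can now be read separately. Nothing measured here offers an explanation for either result.

On these data alone, each change rests on one pair only, so it remains open whether either result would hold on other parts of the series. As far as these compounds go, it is also open whether a longer chain such as ethoxy, or an amine, at the place of the hydroxy would move the number beyond the scatter.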